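Trimming the Chain Further: From Compound 2 to Compound 3

The source may report more compounds than this note shows. Statements on the series, on what has been measured and on what is new or still open speak of the compounds shown alone.

Measured compounds:
compound 1, `CCCCCCCCCCNC(=O)Nc1c(C(C)C)cccc1C(C)C`, 56 nM
compound 2, `CCCCCCNC(=O)Nc1c(C(C)C)cccc1C(C)C`, 99 nM

In an assay on microsomes from intestinal mucosa for inhibition of acyl-CoA:cholesterol acyltransferase (Oryctolagus cuniculus) (on this read-out lower numbers stand for stronger inhibition and higher numbers for weaker inhibition), compound 1 gives 56 nM and compound 2 gives 99 nM. Of the two numbers, compound 2 carries the higher one, but the step of a 1.8-fold higher number from compound 1 to compound 2 (0.25 log units; within the scatter) lies within the scatter, so no order between the two can be read.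

Compound 3, `CCCCNC(=O)Nc1c(C(C)C)cccc1C(C)C`, follows from compound 2 by hydrogen in place of ethyl on a saturated chain carbon, four bonds along the chain from an amide-type nitrogen. Going by the values given here, the only measured step that bears on this change is a 1.8-fold higher number from compound 1 to compound 2 (0.25 log units; within the scatter), which removed a longer piece of the same chain and moved the number only slightly upward. A smaller cut is therefore expected to give at most a modest rise in this assay, possibly none beyond the scatter. Compound 3 is thus estimated at 180 nM, with a range from 70 nM to 500 nM, corresponding to an expected step of a 1.8-fold higher number from compound 2 to compound 3 (0.26 log units; within the scatter).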

Compound 3, half-maximal inhibitory concentration: 630 nM
The estimate for compound 3 lay 3.5-fold (0.54 log units) below the measured number; measured number above the stated range.
By their numbers in this assay, from the lowest: compounds 1 and 2 (each within the scatter of the next); then compound 3.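

In this assay, going by these compounds alone, hydrogen in place of ethyl, four bonds along the chain from an amide-type nitrogen, gives a 6.4-fold higher number from compound 2 to compound 3 (0.80 log units; beyond the scatter) and so produces the first change that clearly exceeds the scatter. The earlier shortening, with a 1.8-fold higher number from compound 1 to compound 2 (0.25 log units; within the scatter) and hydrogen in place of butyl, gave no readable change, so the chain can be shortened to the length in compound 2 without a readable loss, but shortening it further to compound 3 weakens inhibition. Taken together, the shortening amounts to an 11-fold higher number from compound 1 to compound 3 (1.05 log units; beyond the scatter) and is a large loss, with the readable part of it arising at this last cut. No measurement here explains why the loss appears at this position.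

The compounds shown leave open whether propyl or ethyl in place of the butyl chain of compound 3 would weaken inhibition further. They also leave open how an amine or a carboxylic acid on the chain would shift the number.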